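Fluoro for nitro on a shared core

The source may report more compounds than this note shows. Statements on the series, on what has been measured and on what is new or still open speak of the compounds shown alone.

- compound 1 `CCCCOc1ccccc1C(=O)/C=C/c1cc(OC)cc(OC)c1` gives 13000 nM
- compound 2 `COc1cc(/C=C/C(=O)c2ccccc2[N+](=O)[O-])cc(OC)c1` gives 3700 nM
- compound 3 `COc1cc(/C=C/C(=O)c2ccccc2F)cc(OC)c1` awaits measurement

In a functional assay (Homo sapiens) for inhibition (on this read-out lower numbers stand for stronger inhibition and higher numbers for weaker inhibition), compound 2 holds the lower of the two numbers. The change to compound 3 is fluoro in place of nitro on an aromatic carbon and puts fluoro in place of nitro on an aromatic carbon. Going by the values given here, only one measured step bears on this, a 3.5-fold lower number from compound 1 to compound 2 (0.55 log units; beyond the scatter) and there nitro replaced butoxy. Among the compounds with values here, no measured compound yet carries fluoro, so a modest step towards a higher number is expected in this assay with wide uncertainty. The expected change is a 2.2-fold higher number from compound 2 to compound 3 (0.33 log units; beyond the scatter) as an estimate only. For compound 3 the estimated value is 8000 nM (range 2500 nM to 20000 nM).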

Compound 3, half-maximal inhibitory concentration: 6000 nM
Compound 3: middle estimate off by 1.3-fold (0.12 log units), on the high side; the measured number falls inside the stated range.
By their numbers in this assay, from the lowest: compounds 2 and 3 (each within the scatter of the next); then compound 1.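

In this assay the step of a 1.6-fold higher number from compound 2 to compound 3 (0.21 log units; within the scatter) shows that fluoro and nitro cannot be told apart at this aromatic carbon, even though fluoro has 1 heavy atom and nitro has 3. Fluoro also keeps an advantage over butoxy, with a 2.2-fold lower number from compound 1 to compound 3 (0.34 log units; beyond the scatter) giving a second replacement of butoxy that lies beyond the scatter. Nothing measured here accounts for these differences.

From the compounds shown here alone, whether an amine or a carboxylic acid at this place would match fluoro and nitro or fall back towards butoxy remains open. A chain shorter than butoxy, such as methoxy, is equally untested among these compounds.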